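This account rests on a few compounds, and the source may have more. Where it says the series, first, only, none or still open, it means among the compounds named here.

Compound 1 `Cc1ccc(CC2=NCCN2)cc1` and compound 2 `O=C(CI)Nc1ccc(CC2=NCCN2)cc1` share one core and differ in a single place: compound 2 carries ((iodomethyl)carbonyl)amino in place of methyl on an aromatic carbon. In an ADME assay on the whole organism (thoracic aorta) with Rattus norvegicus as the target (a higher number here means a larger maximal response, a lower number a smaller maximal response), compound 1 gives 14%, and compound 2 gives 25%. For the measured compounds named here, that exchange is the one measured step so far, a number 11 percentage points higher from compound 1 to compound 2 (beyond the scatter). Of the two numbers compound 2 stands highest, with compound 1 as its nearest neighbour at a clearly lower value.

Compound 3 `O=C(CCl)Nc1ccc(CC2=NCCN2)cc1` has not yet been measured. It differs from compound 2 by chloro in place of iodo on a saturated chain carbon bound to a carbonyl carbon. Going by the values given here, no measured step exchanges one halogen for another, so the only step at hand, from methyl to the halogen-bearing side chain, does not bear on this change directly. Replacing one halogen with another, with nothing else added or taken away, is expected to move this assay little, if at all beyond the scatter. Compound 3 is therefore expected to give about 22%, in the range 10% to 35%. The expected step is a number 3 percentage points lower from compound 2 to compound 3 (within the scatter), a small drop that may well sit within the scatter.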

Compound 3, largest response reached (Emax), in percent of the reference or control that the assay uses: 41%
For compound 3 the middle estimate is 19 percentage points below the measured one, outside the stated range (above it).
By their numbers in this assay, from the lowest: compound 1; then compound 2; then compound 3.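

In this assay, the identity of the halogen on the saturated chain carbon bound to a carbonyl carbon matters: chloro in place of iodo gives a number 16 percentage points higher from compound 2 to compound 3 (beyond the scatter), even though the count of hydrogen-bond donors and acceptors and the net charge stay the same. Replacing methyl on an aromatic carbon with ((chloromethyl)carbonyl)amino gives a number 27 percentage points higher from compound 1 to compound 3 (beyond the scatter), a larger gain than the iodo side chain gave, so the gain over methyl depends on which halogen the side chain carries. Nothing available here explains why the two halogens differ.

With only iodo and chloro shown on this carbon, two halogens cannot establish a trend, and it remains open whether bromo or fluoro would give a value between them or outside their range. As far as these compounds go, it also remains open whether the halogen is needed at all, which a plain acetylamino side chain or an amine in its place could test, and whether a longer chain between the carbonyl and the chloro would keep the larger response.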